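The source may report more compounds than this note shows. Statements on the series, on what has been measured and on what is new or still open speak of the compounds shown alone.

In a physicochemical assay for lipophilicity (a lower number here means a more polar compound, a higher number a more lipophilic compound), the measured compounds stand as follows:
compound 1 `CNC(=O)CCC(CC(=O)Nc1ccc(C)cc1C)c1nnc(CCCC(C)C)n1C1CC1` gives 3.5
compound 2 `Cc1ccc(NC(=O)CC(CCC(=O)N(C)C)c2nnc(CCCC(C)C)n2C2CC2)c(C)c1` gives 3.8
compound 3 `Cc1ccc(NC(=O)C[C@H](CCC(=O)O)c2noc(-c3cc(CC(C)C)no3)c2C2CC2)c(Cl)c1` gives 3.8

Compound 3 is level with compound 2 at the digits shown, and together they hold the highest of the three values; the value of compound 1 lies within the scatter of that of compound 3. Compound 4 `Cc1ccc(NC(=O)C[C@H](CCC(=O)O)c2noc(-c3cc(C(F)(F)C(C)(C)C)on3)c2C2CC2)c(Cl)c1` differs from compound 3 in one place: 5-(1,1-difluoro-2,2-dimethylpropyl)-1,2-oxazol-3-yl in place of 3-isobutyl-1,2-oxazol-5-yl on an aromatic carbon. Among the measured compounds shown here, the only measured step, a number 0.30 log units higher from compound 1 to compound 2 (within the scatter), concerns a methyl on an amide nitrogen and does not bear on this swap, so no measured step guides it. The entering group brings more heavy atoms and two fluorines than the leaving group, and an upward step of a number 0.50 log units higher from compound 3 to compound 4 (beyond the scatter) is expected. Compound 4 is therefore estimated at 4.3, between 3.9 and 4.7.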

Compound 4, distribution coefficient: 4.3
Compound 4: the middle estimate sits on the measured number at the digits printed; the range from low to high includes it.
By their numbers in this assay, from the lowest: compounds 1, 2 and 3 (each within the scatter of the next); then compound 4.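

In this assay, among the compounds shown here, the swap of 3-isobutyl-1,2-oxazol-5-yl for 5-(1,1-difluoro-2,2-dimethylpropyl)-1,2-oxazol-3-yl on the aromatic carbon next to the ring oxygen gives a number 0.50 log units higher from compound 3 to compound 4 (beyond the scatter) and is the first step in this set that lies beyond the scatter. The number therefore does respond to a change at this position, although nothing measured here explains the rise.

From the compounds shown here alone, the swap alters the side chain and the way the ring is attached at the same time, so the share of each stays open. Going by these compounds, how an amine on this carbon would read in this assay also stays open.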